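A few compounds are considered here, and "the series" means these few. Any claim that something is new, unique, unknown or untested is made for them only; others in the source may bear on it.

Working notes on the series. Compound 1 `CN(C)CCn1cnnc1-c1cc(Oc2ccc(NC(=O)Nc3cccc(C(F)(F)F)c3)cc2F)ccn1` gives 2150 nM in a functional assay on NCI-H460 cells (Homo sapiens) for antiproliferative activity, read by MTT assay, with a stated time of 72 h; on this read-out lower numbers stand for stronger inhibition and higher numbers for weaker inhibition. Compound 2 `CN(C)CCn1cnnc1-c1cc(Oc2ccc(NC(=O)Nc3ccccc3C(F)(F)F)cc2F)ccn1` shows no number there but only a limit, > 50000 nM, the point noted in the limit of > 50000 nM in this assay, at which 1 of the 2 values shown sits. The one step measured so far, an at least 23-fold higher number from compound 1 to compound 2 (1.36 log units; beyond the scatter), is the replacement of 3-(trifluoromethyl)phenyl by 2-(trifluoromethyl)phenyl on the urea nitrogen, and compound 2 therefore stands at the weak end of the numbers shown.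

Compound 3 `CN(C)CCn1cnnc1-c1cc(Oc2ccc(NC(=O)Nc3ccc(F)c(Cl)c3)cc2F)ccn1` is not yet measured. It differs from compound 2 by 3-chloro-4-fluorophenyl in place of 2-(trifluoromethyl)phenyl on an amide-type nitrogen, that is, 3-chloro-4-fluorophenyl in place of 2-(trifluoromethyl)phenyl on the amide-type nitrogen. Among the measured compounds shown here, the only step that bears on it is the measured one from compound 1 to compound 2, which was large and ran toward the limit; compound 3, like compound 1, no longer carries 2-(trifluoromethyl)phenyl. A large step back toward lower numbers is therefore expected, an at least 20-fold lower number from compound 2 to compound 3 (1.30 log units; beyond the scatter), with compound 3 estimated at 2500 nM in this assay, between 500 nM and 20000 nM.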

Compound 3, half-maximal inhibitory concentration: 1580 nM
Compound 3: middle estimate off by 1.6-fold (0.20 log units), on the high side; the measured number falls inside the stated range.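

The change on the amide-type nitrogen gives an at least 31-fold lower number from compound 2 to compound 3 (1.50 log units; beyond the scatter), so the weak result of compound 2 does not extend to every replacement at this place. 3-Chloro-4-fluorophenyl in place of 3-(trifluoromethyl)phenyl gives a 1.4-fold lower number from compound 1 to compound 3 (0.13 log units; within the scatter), so in this assay two differently substituted phenyl groups cannot be told apart, and activity at this place does not require a trifluoromethyl group. For compound 2 the reading remains a limit of the assay and not a number: the limit of > 50000 nM in this assay, at which 1 of the 3 values shown sits.

What lies behind the loss at compound 2 cannot be read from these values. From the compounds shown here alone, it also remains open whether a plain phenyl, a 3-chlorophenyl, a 4-fluorophenyl or a cyclohexyl group on the same nitrogen would keep the level of compound 1 and compound 3.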